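This account rests on a few compounds, and the source may have more. Where it says the series, first, only, none or still open, it means among the compounds named here.

Measured in a functional assay on MCF7 cells (Homo sapiens) for antiproliferative activity, read by MTT assay, with a stated time of 24 h; on this read-out lower numbers stand for stronger inhibition and higher numbers for weaker inhibition:
- compound 1 `CCn1c(C(=O)N[C@@H](CC(=O)OC)C(=O)OC)ccc1C(CC)(CC)c1ccc(OCS(=O)(=O)c2ccccc2)c(C)c1`: > 50000 nM
- compound 2 `CCn1c(C(=O)N[C@@H](C)CO)ccc1C(CC)(CC)c1ccc(OCS(=O)(=O)c2ccccc2)c(C)c1`: 10800 nM

The entry for compound 1 is a limit of the assay and not a number: the limit of > 50000 nM in this assay, at which 1 of the 2 values shown sits. Among the measured compounds shown here, compound 2, at 10800 nM, therefore holds the only true number so far.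

Compound 3 `CCn1c(C(=O)N[C@H](CO)C(C)C)ccc1C(CC)(CC)c1ccc(OCS(=O)(=O)c2ccccc2)c(C)c1` differs from compound 2 by a single change: isopropyl in place of methyl on a saturated chain carbon bound to an amide-type nitrogen and a saturated chain carbon. In words, isopropyl stands in place of methyl on a saturated chain carbon bound to an amide-type nitrogen and a saturated chain carbon.

For the measured compounds named here, only one measured step bears on this, an at least 4.6-fold lower number from compound 1 to compound 2 (0.66 log units; beyond the scatter). It replaced 1,2-bis(methoxycarbonyl)ethyl with 1-(hydroxymethyl)ethyl, a different exchange, so it gives no firm guide to direction. The expected change is therefore small, within the scatter: a 1.1-fold lower number from compound 2 to compound 3 (0.03 log units; within the scatter). For compound 3 the estimated value is 10000 nM, with an expected range of 4000 nM to 30000 nM.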

Compound 3, half-maximal inhibitory concentration in the MCF7 assay: 25500 nM
Estimate against measurement, compound 3: 2.6-fold (0.41 log units) below; measured number inside the range.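

In the MCF7 assay compound 2 gives 10800 nM and compound 3 gives 25500 nM. At this saturated chain carbon, the MCF7 assay records a 2.4-fold higher number from compound 2 to compound 3 (0.37 log units; beyond the scatter) for isopropyl in place of methyl, the first sign that this carbon itself matters: inhibition weakens modestly, whereas the earlier step exchanged the whole group on the amide-type nitrogen. The step of an at least 1.9-fold lower number from compound 1 to compound 3 (0.29 log units; that floor lies within the scatter) starts from a limit of the assay and not a number, so it gives only a floor that does not clearly separate the two compounds. In a physicochemical assay for solubility, read by HPLC, at pH 7.4 (a lower number here means a less soluble compound, a higher number a more soluble compound), compound 2 gives 35.7 ug/mL and compound 3 gives 27.8 ug/mL. In the physicochemical assay the same change gives a 1.3-fold lower number from compound 2 to compound 3 (0.11 log units; within the scatter) and so leaves the two compounds level on solubility, even though inhibition moved.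

Going by these compounds, with only methyl and isopropyl at this carbon, it stays open whether ethyl would give an intermediate number or a longer chain would weaken inhibition further. An amine or a carboxylic acid on this carbon would show whether anything other than a plain carbon chain is tolerated there.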